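The source may hold more compounds than are shown below. What is called first, only, known or untested is meant among the compounds shown, and "the series" means these compounds.

In a functional assay on SK-BR-3 cells (Homo sapiens) for antiproliferative activity (on this read-out higher numbers stand for weaker inhibition and lower numbers for stronger inhibition), compound 1 (`CC(C)=CCc1cc(C(=O)Nc2cc3ccc(OCCCNC(C)C)c(C)c3oc2=O)ccc1O`) gives 750 nM and compound 2 (`CC(C)=CCc1cc(C(=O)Nc2cc3ccc(OCCCNC(C)(C)C)c(C)c3oc2=O)ccc1O`) gives 660 nM, so compound 2 stands level with compound 1 within the scatter. Compound 3 (`CC(C)=CCc1cc(C(=O)Nc2cc3ccc(OCCCN(C)C(C)(C)C)c(C)c3oc2=O)ccc1O`) differs from compound 2 by methyl in place of hydrogen on an amine nitrogen. Among the measured compounds shown here, the one measured step, a 1.1-fold lower number from compound 1 to compound 2 (0.06 log units; within the scatter), also brings in a methyl, though on a saturated chain carbon, and stays within the scatter. That single step is only indirect evidence, so no change beyond the scatter is expected, with a wide range. The expected step is a 1.1-fold higher number from compound 2 to compound 3 (0.06 log units; within the scatter). For compound 3 the estimated value is 750 nM, expected between 330 nM and 1700 nM.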

Compound 3, half-maximal inhibitory concentration: 880 nM
Compound 3: the middle estimate sits 1.2-fold (0.07 log units) below what was measured; low and high end bracket the measured number.
By their numbers in this assay, from the lowest: compounds 2, 1 and 3 (each within the scatter of the next).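

In this assay the amine nitrogen takes a methyl in place of its hydrogen with no change beyond the scatter (a 1.3-fold higher number from compound 2 to compound 3 (0.12 log units; within the scatter)). Methyl(tert-butyl)amino also stands level with isopropylamino (a 1.2-fold higher number from compound 1 to compound 3 (0.07 log units; within the scatter)), so the three amines shown on this chain read alike, and the hydrogen on the nitrogen is not needed to hold the number among these compounds. No measurement at hand explains this result. Open remain a piperidine or morpholine on the same chain, a longer chain, and a carboxylic acid in place of the amine.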